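A few compounds are considered here, and "the series" means these few. Any claim that something is new, unique, unknown or untested is made for them only; others in the source may bear on it.

Compounds measured so far:
- compound 1, `O=C1C(NC2CCCC2)=CC(=O)c2c1nc1n2[C@H]2OC[C@@H](O)[C@H]2OC1`, > 16000 nM
- compound 2, `O=C1C=C(Nc2ccccc2)C(=O)c2c1nc1n2[C@H]2OC[C@@H](O)[C@H]2OC1`, 1730 nM

In a functional assay on MGC-803 cells (Homo sapiens) for inhibition, read by sulforhodamine B assay (on this read-out higher numbers stand for weaker inhibition and lower numbers for stronger inhibition), compound 1 gives > 16000 nM, and this is a limit of the assay rather than a measured number: compound 1 shows no measurable inhibition up to that point, so it sits at the weakest end of what the assay can report (the limit of > 16000 nM in this assay, at which 1 of the 2 values shown sits). Compound 2 carries a phenylamino group in place of the cyclopentylamino group and, in this assay, compound 2 gives 1730 nM, a clear number within the measurable range.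

Compound 3, `O=C1C(Nc2cccc(Cl)c2)=CC(=O)c2c1nc1n2[C@H]2OC[C@@H](O)[C@H]2OC1`, has not yet been measured. Compared with compound 1 the change is 3-chlorophenyl in place of cyclopentyl on an amine nitrogen. Among the measured compounds shown here, compound 1 offers only a limit, so no measured step between related compounds is available to set the size of this change; what can be said is that the one arylamino compound measured, compound 2, lies inside the range of the assay while the cyclopentylamino compound 1 does not. On that basis, compound 3 is expected to give a measurable value, with the step of an at least 6.4-fold lower number from compound 1 to compound 3 (0.80 log units; beyond the scatter) expected to move it toward stronger inhibition. The estimate for compound 3 is 2500 nM, within 700 nM to 9000 nM.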

Compound 3, half-maximal inhibitory concentration: 1530 nM
The estimate for compound 3 lay 1.6-fold (0.21 log units) above the measured number; the measured number falls inside the stated range.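

On an amine nitrogen of this core, putting 3-chlorophenyl in place of cyclopentyl gives a compound with a measurable value in this assay, with an at least 10-fold lower number from compound 1 to compound 3 (1.01 log units; beyond the scatter). This is the first pair shown in which only one group differs, so the change in inhibition can be tied to this swap rather than to any other part of the molecule. Compound 1 gives > 16000 nM, which is a limit and not a number, so the size of the step is only a minimum: the limit of > 16000 nM in this assay, at which 1 of the 3 values shown sits.

The swap replaces a non-aromatic five-membered ring with an aromatic six-membered ring and adds a chlorine at the same time, so these compounds cannot show whether the aromatic ring, the chlorine or both account for the step, and compound 2 differs from compound 3 in more than one place, so it cannot settle this. Also open, from the compounds shown here alone, is how inhibition would respond to another group on the phenyl ring at this same place on the core, such as a methoxy group or a carboxylic acid.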